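A few compounds are considered here, and "the series" means these few. Any claim that something is new, unique, unknown or untested is made for them only; others in the source may bear on it.

Measured compounds:
compound 1 `CCCCCC(=O)Nc1cc(-c2ccccc2)c(-c2ccccc2)nn1`: > 300000 nM (a limit of the assay, not a number)
compound 2 `CCCCCCCSc1cc(-c2ccccc2)c(-c2ccccc2)nn1`: 76000 nM

Going by the values given here, in an assay on microsomes from liver for inhibition of sterol O-acyltransferase 1 (Rattus norvegicus) (a lower number here means a stronger inhibitor, a higher number a weaker inhibitor), compound 2 holds the only number measured. Compound 1 reaches only a limit of the assay, (the limit of > 300000 nM in this assay, at which 1 of the 2 values shown sits). Among the compounds with values here, the one measured step, an at least 3.9-fold lower number from compound 1 to compound 2 (0.59 log units; beyond the scatter), concerns a different exchange and does not test the change now in hand. Compound 3 `CCCCCC[S+]([O-])c1cc(-c2ccccc2)c(-c2ccccc2)nn1` differs from compound 2 by a group of 8 heavy atoms (6 carbon, 1 oxygen, 1 sulfur; no ring) in place of a group of 8 heavy atoms (7 carbon, 1 sulfur; no ring), on an aromatic carbon. Within the data shown here, with no measured step bearing on this change, a step from compound 2 to compound 3 no larger than modest is expected in this assay, a 1.3-fold higher number from compound 2 to compound 3 (0.12 log units; within the scatter). Compound 3 is therefore estimated at 100000 nM, within 30000 nM to 400000 nM.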

Compound 3, half-maximal inhibitory concentration: 75000 nM
The estimate for compound 3 lay 1.3-fold (0.12 log units) above the measured number; low and high end bracket the measured number.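

In this assay, placing the oxygen-bearing sulfur group of compound 3 on this aromatic carbon instead of heptylsulfanyl gives a 1.0-fold lower number from compound 2 to compound 3 (0.01 log units; within the scatter), so adding oxygen to the sulfur while shortening the chain leaves no readable change. A second sulfur-linked group also gives an at least 4.0-fold lower number from compound 1 to compound 3 (0.60 log units; beyond the scatter), so the difference from (pentylcarbonyl)amino does not rest on heptylsulfanyl alone. The value of compound 1 behind that step is a limit of the assay, not a number: the limit of > 300000 nM in this assay, at which 1 of the 3 values shown sits.

From the compounds shown here alone, whether an amine, a carboxylic acid or a longer chain on this carbon would lower the number remains open. So does the effect of a second oxygen on the sulfur.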